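A Methyl Added to the Phenyl Ring of Compound 3

The source may report more compounds than this note shows. Statements on the series, on what has been measured and on what is new or still open speak of the compounds shown alone.

Of the compounds shown here, three of one family have been tested in an assay on CHO cells for displacement of a labelled ligand from adenosine receptor A1 (Homo sapiens), read by scintillation counting, with a stated time of 120 min, tested at 1 uM; on this read-out lower numbers stand for less inhibition and higher numbers for more inhibition at the one concentration tested (going by the name of the read-out). Compound 1 `Cc1ccc(-c2nc3c(=O)[nH]c(C)nc3s2)cc1` gives 17% in this assay. Compound 2 `Cc1ccc(Nc2nc3c(=O)[nH]c(C)nc3s2)cc1` gives 20%. Compound 3 `CCOc1nc(C)nc2sc(-c3ccccc3)nc12` gives 11%. Compound 3 carries the lowest figure of the three, but the gaps to compound 1 and to compound 2 both lie within the usual scatter of repeated measurements, so the three numbers cannot be told apart with confidence and are best taken as level.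

Compound 4 `CCOc1nc(C)nc2sc(-c3ccc(C)cc3)nc12` has not yet been measured. Compared with compound 3 it differs in one place: methyl in place of hydrogen on an aromatic carbon. Among the measured compounds shown here, no pair of measured compounds differs by exactly this change, so there is no measured step to lean on. Because compound 3 gives 11% and all three measured numbers cluster closely, a step from compound 3 to compound 4 of a number 2 percentage points higher from compound 3 to compound 4 (within the scatter) is expected, which is no change beyond the scatter. Compound 4 is therefore estimated to give 13% in this assay, with a range from 3% to 25%.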

Compound 4, a percentage reported as inhibition, at one concentration (the size of the read-out at that concentration, not a potency): 1%
The estimate for compound 4 lay 12 percentage points above the measured number, outside the stated range (below it).
By their numbers in this assay, from the lowest: compounds 4, 3, 1 and 2 (each within the scatter of the next, the first and the last beyond it).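

Methyl in place of hydrogen on an aromatic carbon, para to a large group, now has a measured step of its own: in this assay it amounts to a number 10 percentage points lower from compound 3 to compound 4 (within the scatter). Among the compounds shown here, this is the first direct reading of this change at this position, and it shows that the added methyl brings no gain in inhibition at the one concentration tested, although the pair cannot be told apart with confidence. For the compounds shown here, nothing measured so far offers an explanation for how the two numbers relate.

Still open, from the compounds shown here alone, is whether a different group at this place, such as a chlorine atom, a methoxy group or an amine, would give a step beyond the scatter. Also open, going by these compounds, is how the same methyl would read on the other carbons of this ring.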